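Group exchange on sulfur, followed from compound 2

The source may report more compounds than this note shows. Statements on the series, on what has been measured and on what is new or still open speak of the compounds shown alone.

In a physicochemical assay for lipophilicity (on this read-out higher numbers stand for higher lipophilicity and lower numbers for lower lipophilicity), compound 1 `CCCCCCN(CCCCCSc1nc2ccccc2o1)C(=O)Nc1ccc(F)cc1F` gives 7.18 and compound 2 `CCCCCCCN(CCCCCSc1nc(O)c2ccccc2n1)C(=O)Nc1ccc(F)cc1F` gives 6.17 as the lower of the two numbers. The gap between them lies beyond the usual scatter. The two compounds differ in more than one place, so that gap cannot be assigned to any single change.

Compound 3 `CCCCCCCN(CCCCCSc1n[nH]c(-c2ccccc2)n1)C(=O)Nc1ccc(F)cc1F` has not yet been measured. It carries 5-phenyl-1H-1,2,4-triazol-3-yl in place of 4-hydroxyquinazolin-2-yl on a sulfur and otherwise matches compound 2.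

Within the data shown here, no measured pair isolates this exchange, so the expectation rests on thin evidence. Compound 2 at 6.17 sits at the bottom of the small range seen so far, and compound 1 at 7.18 marks its top. A moderate rise is expected, with the result staying inside or close to that range, though no change beyond the scatter remains possible. The estimated step of a number 0.63 log units higher from compound 2 to compound 3 (beyond the scatter) is upward and modest in size. Compound 3 is expected at 6.8 with an estimated range from 6.1 to 7.5 for now.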

Compound 3, partition coefficient: 6.78
For compound 3 the middle estimate is 0.02 log units above the measured one; measured number inside the range.
By their numbers in this assay, from the lowest: compound 2; then compound 3; then compound 1.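

Notes on the sulfur position: in this assay the exchange of 4-hydroxyquinazolin-2-yl for 5-phenyl-1H-1,2,4-triazol-3-yl gives a number 0.61 log units higher from compound 2 to compound 3 (beyond the scatter) and provides the first reading of a change in one place, with the rest of compound 2 held fixed. The gap between compound 1 and compound 2 could not show this, as those two differ in more than one place; the group on sulfur can now be said to move this read-out on its own, even where heavy-atom count, hydrogen-bond donor count and net charge stay as they were and the ring make-up and hydrogen-bond acceptor count change from 3 to 2. Nothing available bears on what lies behind this step.

Compound 1 differs from compound 3 in more than one place, so the contribution of its group on sulfur remains unresolved, as does whether the step carries over to other chains on the urea nitrogen. Also open, going by these compounds, is how a non-aromatic group on the same sulfur, such as an amine or a carboxylic acid, would compare with 4-hydroxyquinazolin-2-yl and 5-phenyl-1H-1,2,4-triazol-3-yl.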